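Ester Chain Growth on Compound 3

The source may report more compounds than this note shows. Statements on the series, on what has been measured and on what is new or still open speak of the compounds shown alone.

Compound 1 `CCOC(=O)C1=C(C)N/C(=N\C#N)NC1c1ccsc1`: 461 nM
Compound 2 `CCOC(=O)C1=C(C)N/C(=N\C#N)NC1c1cccs1`: 51 nM
Compound 3 `CCOC(=O)C1=C(C)N/C(=N\C#N)NC1c1ccoc1`: 102 nM

Of the compounds shown here, three sharing one core have been measured in an assay on HEK293 cells for displacement of a labelled ligand from adenosine receptor A2b (Homo sapiens), with a stated time of 30 min (a lower number here means a stronger inhibitor, a higher number a weaker inhibitor), and they differ only in the ring attached to a saturated ring carbon. Compound 3 holds the second highest of the three numbers. Its nearest neighbour is compound 2, separated by a 2.0-fold higher number from compound 2 to compound 3 (0.30 log units; within the scatter), a gap that stays within the scatter of this assay. Its furthest neighbour is compound 1, separated by a 4.5-fold lower number from compound 1 to compound 3 (0.66 log units; beyond the scatter), a gap that lies beyond the scatter. The third measured step, a 9.0-fold lower number from compound 1 to compound 2 (0.96 log units; beyond the scatter), also concerns the ring on the saturated ring carbon.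

Compound 4 `CC1=C(C(=O)OC(C)C)C(c2ccoc2)N/C(=N/C#N)N1` is the next compound to be measured. It differs from compound 3 by methyl in place of hydrogen on a saturated chain carbon bound to an oxygen next to a carbonyl group and a saturated chain carbon. None of the three measured steps touches this part of the molecule; all of them exchange the ring on the saturated ring carbon while the ester is kept the same. Among the measured compounds shown here, there is therefore no measured step that bears on the change from compound 3 to compound 4, and the expectation rests on the absence of evidence for any effect. The step is expected to stay within the scatter: a 1.2-fold higher number from compound 3 to compound 4 (0.07 log units; within the scatter). Compound 4 is thus estimated at 120 nM, with a range from 40 nM to 360 nM.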

Compound 4, inhibition constant: 59.4 nM
For compound 4 the middle estimate is 2.0-fold (0.31 log units) above the measured one; the measured number falls inside the stated range.
By their numbers in this assay, from the lowest: compounds 2, 4 and 3 (each within the scatter of the next); then compound 1.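

In this assay, among the compounds shown here, exchanging ethoxycarbonyl for isopropoxycarbonyl, with furan-3-yl kept on the saturated ring carbon, gives a 1.7-fold lower number from compound 3 to compound 4 (0.23 log units; within the scatter), the only reading so far of a change in the ester, since the other three compounds all carry ethoxycarbonyl. At this position, then, methyl in place of hydrogen on the saturated chain carbon bound to the oxygen moves the number no further than the scatter, whereas exchanging the ring on the saturated ring carbon can go beyond it, as in a 9.0-fold lower number from compound 1 to compound 2 (0.96 log units; beyond the scatter). Nothing is available that would explain this result.

As far as these compounds go, the ester change has been read only with furan-3-yl, so it remains open whether ethoxy to isopropoxy would also stay within the scatter with the thiophen-2-yl of compound 2 or the thiophen-3-yl of compound 1. Also open, from the compounds shown here alone, is how far this position tolerates larger or different groups, such as a longer chain like butyl, a benzyl ester, or a carboxylic acid in place of the ester.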